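The compounds below may be only part of what the source reports. "The series", "measured", "known", "first", "only" and "open" are said of these compounds alone.

Working notes on the series, read in a functional assay on HL-60 cells (Homo sapiens) for antiproliferative activity, read by MTT assay, with a stated time of 72 h; a higher number here means a weaker inhibitor, a lower number a stronger inhibitor. Compound 1 `COc1cc(-n2ncnc2-c2ccc(C)cc2)cc(OC)c1OC` gives 90 nM. Compound 2 `COc1cc(-n2ncnc2-c2ccc(Cl)c(Cl)c2)cc(OC)c1OC` reads > 10000 nM, which is a limit of the assay and not a number. Going by the values given here, compound 3 `CCOc1ccc(-c2ncnn2-c2cc(OC)c(OC)c(OC)c2)cc1` gives 20 nM, the lowest number so far. Compound 4 `COc1cc(-n2ncnc2-c2ccc(SC)cc2)cc(OC)c1OC` is the next to read, with methylsulfanyl in place of ethoxy on an aromatic carbon, para to a large group: methylsulfanyl in place of ethoxy on an aromatic carbon.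

Among the compounds with values here, two measured steps bear on this change. The closer guide is the modest 4.5-fold lower number from compound 1 to compound 3 (0.65 log units; beyond the scatter), an exchange of one group on the aromatic carbon. The large at least 110-fold higher number from compound 1 to compound 2 (2.04 log units; beyond the scatter) replaces 4-methylphenyl with 3,4-dichlorophenyl, a change of a different kind, and it shows that a much greater loss is possible within the series. A modest move towards a higher number is therefore expected in this assay, on the scale of the first step rather than the second. The expected step is a 2.3-fold higher number from compound 3 to compound 4 (0.35 log units; beyond the scatter). For compound 4 the estimate is 45 nM, with an expected range of 10 nM to 300 nM.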

Compound 4, half-maximal inhibitory concentration: 500 nM
Estimate against measurement, compound 4: 11-fold (1.05 log units) below; the whole stated range lies below it.
By their numbers in this assay, from the lowest: compound 3; then compound 1; then compound 4. At a limit, above all of these: compound 2.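

In this assay, methylsulfanyl on the aromatic carbon para to a large group gives a 25-fold higher number from compound 3 to compound 4 (1.40 log units; beyond the scatter) and also a 5.6-fold higher number from compound 1 to compound 4 (0.74 log units; beyond the scatter), so this position separates the three groups placed there so far. Ethoxy and methylsulfanyl each count one hydrogen-bond acceptor and no donor, yet that shared count does not keep their numbers together. Compound 2 reads as a limit of the assay and not a number, so an at least 20-fold lower number from compound 2 to compound 4 (1.30 log units; beyond the scatter) is only a bound, and it spans a change of more than one substituent: the limit of > 10000 nM in this assay, at which 1 of the 4 values shown sits.

Going by these compounds, whether methoxy, propoxy or an amine on this carbon would read nearer compound 3 or nearer compound 4 stays open. Also open, on these data alone, is how a single chlorine at this position would read, as the 3,4-dichlorophenyl of compound 2 does not separate the two chlorines.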